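Methoxy in place of methyl on compound 2

This account rests on a few compounds, and the source may have more. Where it says the series, first, only, none or still open, it means among the compounds named here.

Of the compounds shown here, two have numbers so far in a functional assay on RKO cells (Homo sapiens) for cytotoxicity, read by resazurin assay, with a stated time of 72 h; on this read-out lower numbers stand for stronger inhibition and higher numbers for weaker inhibition. Compound 1 (`COc1ccc(Nc2nc(-n3ccnc3C)cs2)cc1`) gives 1600 nM and compound 2 (`Cc1ccc(Nc2nc(-n3cc(C)nc3C)cs2)cc1`) gives 200 nM as the lower of the two numbers, with a gap beyond the scatter. These two compounds differ in more than one place, so their gap assigns nothing to a single change. Compound 3 (`COc1ccc(Nc2nc(-n3cc(C)nc3C)cs2)cc1`) has methoxy in place of methyl on an aromatic carbon of compound 2 (methoxy in place of methyl on an aromatic carbon), para to a large group. Going by the values given here, no single-place step has been measured. A higher number in this assay is expected, because compound 1 at 1600 nM also carries methoxy, though the size of the rise is uncertain. The estimated step of a 1.8-fold higher number from compound 2 to compound 3 (0.24 log units; within the scatter) is expected to lie near the edge of the scatter. Compound 3 is estimated at 350 nM (expected range 120 nM to 1000 nM).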

Compound 3, half-maximal inhibitory concentration: 250 nM
For compound 3 the middle estimate is 1.4-fold (0.15 log units) above the measured one, within the range that was stated.
By their numbers in this assay, from the lowest: compounds 2 and 3 (each within the scatter of the next); then compound 1.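

In this assay methoxy in place of methyl on an aromatic carbon, para to a large group, gives a 1.3-fold higher number from compound 2 to compound 3 (0.10 log units; within the scatter) and so leaves no readable difference between these two groups at this position. The large gap in this short series instead sits with the other change, methyl in place of hydrogen on an aromatic carbon, which gives a 6.4-fold lower number from compound 1 to compound 3 (0.81 log units; beyond the scatter) as a single-place step, with methoxy present on both compounds. Nothing at hand bears on the reason for either step.

Open, from the compounds shown here alone, is whether this tolerance at the position extends beyond methyl and methoxy to a longer chain such as butoxy, or to an amine or a carboxylic acid. Also open, going by these compounds, is whether the methyl step holds with methyl rather than methoxy at this position.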